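The compounds below may be only part of what the source reports. "The series", "measured", "known", "first", "only" and "open" are said of these compounds alone.

Compound 2 `C[C@H](NC(=O)C(=O)NCc1ccc(F)cc1)C(=O)N[C@@H](CC(=O)O)C(=O)COc1c(F)c(F)cc(F)c1F` stands at 197 nM in a functional assay on Jurkat cells (Homo sapiens) (on this read-out higher numbers stand for weaker inhibition and lower numbers for stronger inhibition), as the higher of two numbers, with compound 1 `C[C@H](NC(=O)C(=O)Nc1cccnc1N(C)C)C(=O)N[C@@H](CC(=O)O)C(=O)COc1c(F)c(F)cc(F)c1F` at 27 nM on the same read-out. Going on to compound 3 `Cc1ccc(C)c(CNC(=O)C(=O)N[C@@H](C)C(=O)N[C@@H](CC(=O)O)C(=O)COc2c(F)c(F)cc(F)c2F)c1` the change is 2,5-dimethylphenyl in place of 4-fluorophenyl on a saturated chain carbon bound to an amide-type nitrogen and leaves the rest of the molecule untouched. Among the measured compounds shown here, the only measured step of a 7.3-fold higher number from compound 1 to compound 2 (0.86 log units; beyond the scatter) is modest and replaces a different group, so it bears only indirectly. For the measured compounds named here, no measured pair exchanges one benzyl group for another. No shift beyond the scatter is therefore expected in this assay for this change. The expected step is a 1.2-fold lower number from compound 2 to compound 3 (0.09 log units; within the scatter) in size. Compound 3 is estimated at 160 nM with an expected range of 60 nM to 420 nM on this read-out.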

Compound 3, half-maximal inhibitory concentration: 11 nM
For compound 3 the middle estimate is 15-fold (1.16 log units) above the measured one; the whole stated range lies above it.
By their numbers in this assay, from the lowest: compound 3; then compound 1; then compound 2.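

In this assay the group on a saturated chain carbon bound to an amide-type nitrogen proves sensitive to its ring substituents: 2,5-dimethylphenyl in place of 4-fluorophenyl gives an 18-fold lower number from compound 2 to compound 3 (1.25 log units; beyond the scatter) with no other change. A benzyl-type group can also improve on 2-(dimethylamino)pyridin-3-yl, with a 2.5-fold lower number from compound 1 to compound 3 (0.39 log units; beyond the scatter) for the 2,5-dimethylbenzyl group, whereas 4-fluorobenzyl went the other way. Nothing available explains the size of either step.

The fluorine leaves and both methyl groups enter together, so the step cannot be assigned to any one of them. An unsubstituted benzyl group, or a benzyl group carrying a single methyl, would separate these contributions.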